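A few compounds are considered here, and "the series" means these few. Any claim that something is new, unique, unknown or untested is made for them only; others in the source may bear on it.

Working notes on the series, read in a physicochemical assay for solubility; on this read-out lower numbers stand for lower solubility and higher numbers for higher solubility. Compound 1 (`CNC(=O)c1cc(C(=O)NC2CC2)cc2c1OC[C@H]2c1cccc2[nH]ccc12`) gives >= 142 ug/mL, which is a limit. Compound 2 (`CNC(=O)c1cc(C(N)=O)cc2c1OC[C@H]2c1ccccc1`) gives >= 144 ug/mL, also a limit. Compound 3 (`CNC(=O)c1cc(C(N)=O)cc2c1O[C@H](CF)[C@H]2c1ccccc1`) gives >= 128 ug/mL, again a limit, so compound 3 has no number of its own to start from.

The next compound is compound 4 (`CNC(=O)c1cc(C(=O)N[C@@H]2C[C@H]2C)cc2c1O[C@H](CF)[C@H]2c1ccccc1`), and the change is 2-methylcyclopropyl in place of hydrogen on an amide-type nitrogen. For the measured compounds named here, the one measured step is a step that the two limits leave unreadable from compound 2 to compound 3. It concerns a saturated ring carbon, not the amide-type nitrogen, and gives no size to carry over. Going by the values given here, no measured step isolates a change at the amide-type nitrogen.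

The nearest evidence is compound 1, which also carries a substituent on an amide-type nitrogen but differs from compound 3 elsewhere too. Compound 1 still reads >= 142 ug/mL, a limit, so this gives no sign of a large loss in this assay.

A small downward move is expected, though it may not exceed the scatter, and the estimated step is an at least 1.0-fold lower number from compound 3 to compound 4 (0.02 log units; that floor lies within the scatter). Compound 4 is estimated at 120 ug/mL, with an expected range of 50 ug/mL to 180 ug/mL. Another limit would not be a surprise.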

Compound 4, solubility: 7 ug/mL
Estimate against measurement, compound 4: 17-fold (1.23 log units) above, outside the stated range (below it).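

Placing 2-methylcyclopropyl on the amide-type nitrogen gives an at least 18-fold lower number from compound 3 to compound 4 (1.26 log units; beyond the scatter) in this assay, which shows that this position can carry a large change in the read-out, something the earlier compounds could not show. Compound 4, at 7 ug/mL, is the only compound shown with a number of its own rather than a limit, so this is the only readable step in the series so far. The size of the step is a floor and not a measured distance, as compound 3 gives only a limit: the limit of >= 128 ug/mL in this assay, at which 1 of the 4 values shown sits.

On these data alone, whether the drop belongs to the cyclopropyl ring, to its methyl or to the arrangement of its defined stereocentres stays open, and the step from compound 2 to compound 3 cannot be read, so any part played by the fluoromethyl group stays open as well. A plain ethyl chain, a longer chain, or a chain ending in an amine or a carboxylic acid on the same amide-type nitrogen would show whether a large step follows any group placed there.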